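The source may hold more compounds than are shown below. What is called first, only, known or untested is meant among the compounds shown, and "the series" means these compounds.

Compound 3 `Cc1nc(-c2ccc(C(F)(F)F)cc2)sc1CNc1ccc(CC(C)C(=O)O)cc1` stands at the top of the three values measured in a functional assay on CHO cells for agonist activity at Free fatty acid receptor 1 (Homo sapiens), read by a luciferase reporter (on this read-out higher numbers stand for larger maximal responses and lower numbers for smaller maximal responses), where compound 3 gives 100%. Compound 2 `Cc1nc(-c2ccc(C(F)(F)F)cc2)sc1CNc1ccc(/C=C/C(=O)O)cc1` sits within the scatter of it: in this assay compound 2 gives 95%, and the step of a number 5 percentage points higher from compound 2 to compound 3 (within the scatter). Compound 1 `Cc1nc(-c2ccc(C(F)(F)F)cc2)sc1CNc1ccc(CC(=O)O)cc1` lies far off; in this assay compound 1 gives 18%. Two large steps lead up from it, a number 77 percentage points higher from compound 1 to compound 2 (beyond the scatter) and a number 82 percentage points higher from compound 1 to compound 3 (beyond the scatter).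

Compound 4 `Cc1nc(-c2ccc(C(F)(F)F)cc2)sc1CNc1ccc(CCC(N)=O)cc1` has not yet been measured. It differs from compound 3 by carbamoylmethyl in place of 1-carboxyethyl on a saturated chain carbon bound to an aromatic carbon. Among the compounds with values here, of the measured steps, only the step from compound 1 to compound 3 acts at the same place, a saturated chain carbon bound to an aromatic carbon, and it was large. Every measured compound, however, keeps a carboxylic acid, and none exchanges it for an amide, so there is no direct guide for the entry of carbamoylmethyl. From the compounds shown here alone, a step downward is judged more likely than none, because compound 1 gives 18% after a change at this same chain, but its size remains open. Compound 4 is therefore expected to give about 45%, between 10% and 90%, an expected step of a number 55 percentage points lower from compound 3 to compound 4 (beyond the scatter).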

Compound 4, largest response reached (reported as percent of maximum), in percent of the reference or control that the assay uses: 88%
Compound 4: the middle estimate sits 43 percentage points below what was measured, and the stated range covers the measured number.
By their numbers in this assay, from the lowest: compound 1; then compounds 4, 2 and 3 (each within the scatter of the next, the first and the last beyond it).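

Compound 4 shows that a carboxylic acid is not required on this chain for a high maximal response in this assay: carbamoylmethyl in place of 1-carboxyethyl on a saturated chain carbon bound to an aromatic carbon gives a number 12 percentage points lower from compound 3 to compound 4 (beyond the scatter), a modest step and the first exchange of the acid among these compounds. The amide also holds up against the unsaturated acid, since 2-carbamoylethyl in place of 2-carboxyethenyl gives a number 7 percentage points lower from compound 2 to compound 4 (within the scatter), so this change leaves the response at the level of compound 2. The step of a number 70 percentage points higher from compound 1 to compound 4 (beyond the scatter) shows that the acid alone does not decide the response, as compound 1 carries one and stays far lower than the amide compound 4. No measurement at hand accounts for how well the amide performs here. Left open is how an amine, a nitrile or a longer chain would fare at this place, and whether the response of the amide would survive on the shorter chain of compound 1 or with the methyl branch of compound 3.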